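From Dichlorophenyl to Difluorophenyl: an Expected Value

The compounds below may be only part of what the source reports. "The series", "measured", "known", "first", "only" and "open" are said of these compounds alone.

Measured so far:
compound 1 `Nc1scc(CN2CCN(c3ccc(Cl)cc3Cl)CC2)c1C(=O)c1ccc(Cl)cc1`: -11%
compound 2 `Nc1scc(CN2CCN(C3CCCCCC3)CC2)c1C(=O)c1ccc(Cl)cc1`: 13%

In a functional assay on CHO cells with adenosine receptor A1 (Homo sapiens) as the target, read by cAMP accumulation and immunoassay, with a stated time of 6 min, tested at 0.1 uM (a lower number here means a stronger effect, a higher number a weaker effect of the compound at the concentration tested), compound 1 gives -11%, the lower of the two numbers; compound 2 gives 13% in this assay, and the step is a number 24 percentage points higher from compound 1 to compound 2 (beyond the scatter). Compound 3 `Nc1scc(CN2CCN(c3ccc(F)cc3F)CC2)c1C(=O)c1ccc(Cl)cc1` differs from compound 1 thus: 2,4-difluorophenyl in place of 2,4-dichlorophenyl on an amine nitrogen in a ring. No measured step exchanges one halogen for another on this group, so the only step shown is an indirect guide at best. A change within the scatter is therefore expected, put at a number 11 percentage points higher from compound 1 to compound 3 (beyond the scatter). Compound 3 is estimated at 0% in this assay, between -20% and 20%.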

Compound 3, a percentage reported as activity, at one concentration (the size of the read-out at that concentration, not a potency): -17%
Compound 3: the middle estimate sits 17 percentage points above what was measured, and the stated range covers the measured number.
By their numbers in this assay, from the lowest: compounds 3 and 1 (each within the scatter of the next); then compound 2.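

In this assay the exchange of 2,4-dichlorophenyl for 2,4-difluorophenyl on an amine nitrogen in a ring gives a number 6 percentage points lower from compound 1 to compound 3 (within the scatter) so the two halogen pairs cannot be told apart at this place. The gap to the cycloheptyl group now appears with a second halogenated phenyl group, as a number 30 percentage points lower from compound 2 to compound 3 (beyond the scatter) shows in the same direction as the earlier step. Nothing available gives a reason for either result. Still open is whether halogens matter here at all, since an unsubstituted phenyl group or a 2,4-dimethoxyphenyl group on this nitrogen is not among the compounds shown.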